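This account rests on a few compounds, and the source may have more. Where it says the series, first, only, none or still open, it means among the compounds named here.

Compound 1 `O=C(Nc1cccc(-n2cc(-c3ccncc3)c(-c3ccc(Cl)c(O)c3)n2)c1)Nc1ccc(Cl)c(Cl)c1` and compound 2 `COc1cc(-c2nn(-c3cccc(NC(=O)c4cccc(C(F)(F)F)c4)c3)cc2-c2ccncc2)ccc1Cl` share one core and were both tested in a functional assay on DU-145 cells (Homo sapiens) for inhibition, read by sulforhodamine B assay, with a stated time of 48 h; a lower number here means a stronger inhibitor of growth, a higher number a weaker inhibitor of growth. Compound 1 reaches only > 32500 nM, a limit rather than a number, as the limit of > 32500 nM in this assay, at which 1 of the 2 values shown sits, records. Compound 2 gives 32100 nM, the only number shown, and it stands as a weak inhibitor of growth. Compound 3 `COc1cc(-c2nn(-c3cccc(NC(=O)c4ccccc4)c3)cc2-c2ccncc2)ccc1Cl` differs from compound 2 by hydrogen in place of trifluoromethyl on an aromatic carbon. Within the data shown here, no measured pair shows this change, so the step of a 1.0-fold lower number from compound 2 to compound 3 (0.00 log units; within the scatter) is expected to stay within the scatter. Compound 3 is therefore estimated at 32000 nM, with a range from 14000 nM to 70000 nM.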

Compound 3, concentration for total growth inhibition: 54700 nM
The estimate for compound 3 lay 1.7-fold (0.23 log units) below the measured number, and the stated range covers the measured number.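

Replacing trifluoromethyl with hydrogen on this aromatic carbon gives a 1.7-fold higher number from compound 2 to compound 3 (0.23 log units; within the scatter) in this assay, so the change from 3-(trifluoromethyl)phenyl to phenyl has no clear effect on this read-out. At this position, the four heavy atoms of trifluoromethyl can be removed without a loss that stands out from ordinary assay variation. Nothing shown here explains this result. On these data alone, whether an amine or a carboxylic acid on the same carbon would give a stronger inhibitor of growth remains open.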